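This account rests on a few compounds, and the source may have more. Where it says the series, first, only, none or still open, it means among the compounds named here.

Compound 1 `O=S(=O)(c1ccccc1)c1c(OCCCCCCO)no[n+]1[O-]`: "not determined" (no result reported)
Compound 2 `O=C(CCCCCCCOc1no[n+]([O-])c1S(=O)(=O)c1ccccc1)NO`: 2610 nM
Compound 3 `O=C(COCCOc1no[n+]([O-])c1S(=O)(=O)c1ccccc1)NO`: 13400 nM

Going by the values given here, in a functional assay on HCT-116 cells (Homo sapiens) for inhibition, read by MTT assay, with a stated time of 48 h (a higher number here means a weaker inhibitor, a lower number a stronger inhibitor), compound 3 gives 13400 nM, the higher of the only two numbers available. Compound 4 `O=C(NO)OCCOCCOc1no[n+]([O-])c1S(=O)(=O)c1ccccc1` has not yet been measured. It differs from compound 3 as follows: ((hydroxycarbamoyl)oxy)methyl in place of hydroxycarbamoyl on a saturated chain carbon bound to an oxygen on a saturated carbon. Among the compounds with values here, only one measured step bears on this change, a 5.1-fold higher number from compound 2 to compound 3 (0.71 log units; beyond the scatter). Within the data shown here, that modest step involved a different swap, 5-(hydroxycarbamoyl)pentyl to (hydroxycarbamoyl)methoxy, so it is only a loose guide, and no measured compound carries the entering group. A somewhat smaller step toward a lower number is therefore expected in this assay, estimated as a 2.2-fold lower number from compound 3 to compound 4 (0.35 log units; beyond the scatter). For compound 4 the estimated value is 6000 nM, with an expected range of 2000 nM to 18000 nM.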

Compound 4, half-maximal inhibitory concentration: 11700 nM
Compound 4: the middle estimate sits 2.0-fold (0.29 log units) below what was measured; measured number inside the range.
By their numbers in this assay, from the lowest: compound 2; then compounds 4 and 3 (each within the scatter of the next).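

In this assay, placing ((hydroxycarbamoyl)oxy)methyl where hydroxycarbamoyl stood on this saturated chain carbon gives a 1.1-fold lower number from compound 3 to compound 4 (0.06 log units; within the scatter), so the larger end group leaves the reading unchanged within the scatter. The 2-((hydroxycarbamoyl)oxy)ethoxy group, like (hydroxycarbamoyl)methoxy, also stays short of 5-(hydroxycarbamoyl)pentyl, with a 4.5-fold higher number from compound 2 to compound 4 (0.65 log units; beyond the scatter) as the printed gap. Nothing measured here accounts for these results. Going by these compounds alone, whether a carboxylic acid or an amine at the chain end would perform as these end groups do remains open, as does the effect of a chain longer than the one in compound 2.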